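The source may hold more compounds than are shown below. What is called first, only, known or untested is meant among the compounds shown, and "the series" means these compounds.

- compound 1 `O=[N+]([O-])c1cccc(Nc2ncc3c(n2)CCCC3)c1`: 3500 nM
- compound 2 `O=C(Nc1cccc(CN2CCCC2)c1)c1n[nH]c2ccccc12`: 8620 nM
- compound 3 `Cc1ccccc1Nc1ncc2c(n1)CCCC2`: > 10000 nM (a limit)

In a functional assay on MV4-11 cells (Homo sapiens) for inhibition, read by resazurin assay, with a stated time of 72 h (a higher number here means a weaker inhibitor of growth, a lower number a stronger inhibitor of growth), compound 1 gives 3500 nM, the lowest of the numbers shown. The nearest number belongs to compound 2 at 8620 nM, a gap beyond the scatter. Compound 3 reads > 10000 nM, which is a limit of the assay and not a number.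

The next step leads to compound 4 `CCc1cccc(Nc2ncc3c(n2)CCCC3)c1`, which carries ethyl in place of nitro on an aromatic carbon, meta to a large group: ethyl in place of nitro on an aromatic carbon. Within the data shown here, no measured step gauges this change. A moderate step to a higher number in this assay is therefore expected, a weaker inhibitor of growth, resting only on compound 3 at > 10000 nM. The expected step is a 1.7-fold higher number from compound 1 to compound 4 (0.23 log units; within the scatter). Compound 4 is estimated at 6000 nM, with an expected range of 2000 nM to 15000 nM.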

Compound 4, concentration for 50% growth inhibition: 2600 nM
The estimate for compound 4 lay 2.3-fold (0.36 log units) above the measured number; the range from low to high includes it.
By their numbers in this assay, from the lowest: compounds 4 and 1 (each within the scatter of the next); then compound 2. At a limit, above all of these: compound 3.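

In this assay, there is a 1.3-fold lower number from compound 1 to compound 4 (0.13 log units; within the scatter), for ethyl in place of nitro on an aromatic carbon, meta to a large group. At this position, the nitro group, with its nitrogen and oxygen atoms, can therefore give way to an all-carbon ethyl with no readable difference in growth inhibition, so nitro is not needed for activity in this range. Nothing shown here gives a cause for this outcome.

Open, from the compounds shown here alone, is whether an amine, a carboxylic acid or a longer chain on the same carbon would shift the number beyond the scatter. Also open, going by these compounds, is how a methoxy group or a chlorine atom there would compare with the ethyl of compound 4 and the nitro of compound 1.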